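Swapping Ethyl for Amino: Expected Cytotoxicity of Compound 4

A few compounds are considered here, and "the series" means these few. Any claim that something is new, unique, unknown or untested is made for them only; others in the source may bear on it.

Three compounds have been measured in a functional assay on HCT-116 cells (Homo sapiens) for cytotoxicity, read by MTT assay, with a stated time of 48 h; a lower number here means a stronger inhibitor, a higher number a weaker inhibitor:

compound 1 `O=C(/C=C/c1ccc2c(c1)B(O)OC2)c1ccccc1` gives 6100 nM
compound 2 `O=C(/C=C/c1ccc2c(c1)B(O)OC2)c1ccc(I)cc1` gives 11600 nM
compound 3 `CCc1ccc(C(=O)/C=C/c2ccc3c(c2)B(O)OC3)cc1` gives 10900 nM

Among these three numbers, compound 3 holds the second highest. Its nearest neighbour is compound 2, with a 1.1-fold lower number from compound 2 to compound 3 (0.03 log units; within the scatter); the furthest is compound 1, with a 1.8-fold higher number from compound 1 to compound 3 (0.25 log units; within the scatter). Both of those steps stay within the scatter, so the three measured compounds cannot be told apart on these data.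

Compound 4 `Nc1ccc(C(=O)/C=C/c2ccc3c(c2)B(O)OC3)cc1` differs from compound 3 in a single place: amino in place of ethyl on an aromatic carbon. For the measured compounds named here, the steps that bear on this change are the two that alter the same position on the ring. Putting ethyl in place of hydrogen, from compound 1 to compound 3, gave a 1.8-fold higher number from compound 1 to compound 3 (0.25 log units; within the scatter); putting ethyl in place of iodo, from compound 2 to compound 3, gave a 1.1-fold lower number from compound 2 to compound 3 (0.03 log units; within the scatter). Going by the values given here, neither moved the number beyond the scatter, and neither involved a group that brings a hydrogen-bond donor or acceptor, so no measured step speaks directly to amino.

On that footing the expected outcome is no step beyond the scatter, a 1.3-fold lower number from compound 3 to compound 4 (0.11 log units; within the scatter). The estimate for compound 4 in this assay is 8500 nM, with a range from 3000 nM to 25000 nM.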

Compound 4, half-maximal inhibitory concentration: 26100 nM
Estimate against measurement, compound 4: 3.1-fold (0.49 log units) below, and the stated range ends below it.
By their numbers in this assay, from the lowest: compounds 1, 3 and 2 (each within the scatter of the next); then compound 4.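

In this assay, hydrogen, iodo and ethyl on this aromatic carbon could not be told apart, so the position seemed able to take quite different groups without consequence. Amino is the first group here to move the number beyond the scatter, giving a 2.4-fold higher number from compound 3 to compound 4 (0.38 log units; beyond the scatter) and also a 2.3-fold higher number from compound 2 to compound 4 (0.35 log units; beyond the scatter) and a 4.3-fold higher number from compound 1 to compound 4 (0.63 log units; beyond the scatter) in the comparisons with the other two compounds. All three steps point towards a weaker inhibitor, which makes compound 4 the weakest of the four and shows that this position is not indifferent to every change, although nothing available explains the shift.

Amino brings a hydrogen-bond donor and a hydrogen-bond acceptor where ethyl has neither, but a single compound cannot show whether that difference matters or whether the loss is peculiar to amino. A hydroxyl, a methoxy group, a dimethylamino group or a carboxylic acid at the same place would help to separate these possibilities, and the compounds shown leave open how any of them would behave.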